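A few compounds are considered here, and "the series" means these few. Any claim that something is new, unique, unknown or untested is made for them only; others in the source may bear on it.

Compound 1 `Clc1ccc(Cc2nn3cc(-c4ccc(Cl)cc4Cl)nc3s2)cc1` gives 109000 nM in a functional assay on HeLa cells (Homo sapiens) for cytotoxicity, with a stated time of 72 h; on this read-out higher numbers stand for weaker inhibition and lower numbers for stronger inhibition. Compound 3 `Clc1ccc(Cc2nn3c(Br)c(-c4ccc(Cl)cc4Cl)nc3s2)cc1` gives 118000 nM in this assay; the change bromo in place of hydrogen on an aromatic carbon gives a 1.1-fold higher number from compound 1 to compound 3 (0.03 log units; within the scatter).

Compound 2 `O=c1oc2ccccc2cc1-c1cn2nc(Cc3ccc(Cl)cc3)sc2n1` reaches only a limit of > 10000 nM in this assay, one of the values at the limit of > 10000 nM in this assay, at which 1 of the 3 values shown sits. The difference between the core of compound 2 and the core of compound 1 is not broken down here.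

Compound 4 `O=c1oc2ccccc2cc1-c1nc2sc(Cc3ccc(Cl)cc3)nn2c1Br` is not yet measured in this assay. The change bromo in place of hydrogen on an aromatic carbon is the same kind of change as that from compound 1 to compound 3; the place differs only in that the ring atom bearing the bromo's neighbour is described as bearing a large group rather than a 2,4-dichlorophenyl group. For compound 4 the expected step from compound 2 is a step that the limit leaves unreadable from compound 2 to compound 4, resting on the step of a 1.1-fold higher number from compound 1 to compound 3 (0.03 log units; within the scatter). Compound 4 is estimated at 30000 nM, most likely again reported only as a limit.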

Compound 4, half-maximal inhibitory concentration: 4500 nM
Compound 4: middle estimate off by 6.7-fold (0.82 log units), on the high side; measured number below the stated range.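

In this assay, bromo in place of hydrogen on an aromatic carbon gives an at least 2.2-fold lower number from compound 2 to compound 4 (0.34 log units; beyond the scatter), while on the core of compound 1 it gives a 1.1-fold higher number from compound 1 to compound 3 (0.03 log units; within the scatter). The value of compound 2, > 10000 nM, is a limit. The pair of steps neither shows that the size of the change carries from one core to the other nor shows that it fails to carry: the same change on two cores in this assay, a 1.1-fold higher number (0.03 log units; within the scatter) from compound 1 to compound 3 and an at least 2.2-fold lower number (0.34 log units; beyond the scatter) from compound 2 to compound 4; the limit leaves it open whether they differ

Going by these compounds, an exact number for compound 2 remains open, and with it the true size of the step on that core. Also open, on these data alone, is whether chloro, methyl or an amine on the same aromatic carbon would behave like bromo on either core.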